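Swapping the benzyl substituent: from nitro to methoxy

The source may report more compounds than this note shows. Statements on the series, on what has been measured and on what is new or still open speak of the compounds shown alone.

Of the compounds shown here, three sharing one core have been tested in a functional assay on PC-3 cells (Homo sapiens) for cytotoxicity, read by sulforhodamine B assay; on this read-out higher numbers stand for weaker inhibition of growth and lower numbers for stronger inhibition of growth. Compound 1 `COc1cccc(OC)c1OCCNCCOc1ccccc1OCc1ccccc1` gives 76900 nM, the highest of the three numbers. Compound 2 `COc1cccc(OC)c1OCCNCCOc1ccccc1OCc1cccc(Cl)c1` gives 20400 nM, and compound 3 `COc1cccc(OC)c1OCCNCCOc1ccccc1OCc1ccccc1[N+](=O)[O-]` gives 34700 nM, the second highest number, close to compound 2. Compound 4 `COc1cccc(COc2ccccc2OCCNCCOc2c(OC)cccc2OC)c1` differs from compound 3 by 3-methoxyphenyl in place of 2-nitrophenyl on a saturated chain carbon bound to an oxygen on an aromatic ring. Going by the values given here, no measured step involves a methoxy group here; the nearest guides are a 3.8-fold lower number from compound 1 to compound 2 (0.58 log units; beyond the scatter) and a 2.2-fold lower number from compound 1 to compound 3 (0.35 log units; beyond the scatter), both modest, while a 1.7-fold higher number from compound 2 to compound 3 (0.23 log units; within the scatter). Those steps suggest that a single substituent on that ring moves the number only modestly, so compound 4 is expected to stay near compound 3, with a 1.0-fold higher number from compound 3 to compound 4 (0.00 log units; within the scatter). Compound 4 is estimated at 35000 nM, between 12000 nM and 90000 nM.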

Compound 4, concentration for total growth inhibition: 15100 nM
For compound 4 the middle estimate is 2.3-fold (0.37 log units) above the measured one; measured number inside the range.
By their numbers in this assay, from the lowest: compounds 4, 2 and 3 (each within the scatter of the next, the first and the last beyond it); then compound 1.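

Putting methoxy on the benzyl ring gives a 5.1-fold lower number from compound 1 to compound 4 (0.71 log units; beyond the scatter), so a third substituent now gives a lower number than the unsubstituted ring. Methoxy and chloro on this ring are not told apart, with a 1.4-fold lower number from compound 2 to compound 4 (0.13 log units; within the scatter), while 3-methoxyphenyl in place of 2-nitrophenyl gives a 2.3-fold lower number from compound 3 to compound 4 (0.36 log units; beyond the scatter). No accompanying measurement explains these differences.

2-Nitrophenyl and 3-methoxyphenyl differ in both the group and its place on the ring, so the compounds shown cannot separate those two changes. Going by these compounds, whether an amine or a carboxylic acid on this ring would lower the number further remains open.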